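Swapping the anilino substituent in a quinazoline series

The source may report more compounds than this note shows. Statements on the series, on what has been measured and on what is new or still open speak of the compounds shown alone.

Two measured compounds frame this step. Compound 1 `CCCCCCCCNc1nc(SCc2ccc(C(F)(F)F)cc2)nc2ccccc12` gives, in a functional assay on PC-3 cells (Homo sapiens) for cytotoxicity, read by MTT assay, with a stated time of 72 h (on this read-out lower numbers stand for stronger inhibition and higher numbers for weaker inhibition), a value of 10500 nM. Compound 2 `O=[N+]([O-])c1cccc(Nc2nc(SCc3ccc(C(F)(F)F)cc3)nc3ccccc23)c1` gives in this assay a value of 13500 nM, which is the higher of the two numbers, though the step of a 1.3-fold higher number from compound 1 to compound 2 (0.11 log units; within the scatter) is within the scatter, so the two compounds cannot be ordered. Compound 3 `CCOc1ccc(Nc2nc(SCc3ccc(C(F)(F)F)cc3)nc3ccccc23)cc1` is not yet measured; it differs from compound 2 by 4-ethoxyphenyl in place of 3-nitrophenyl on a nitrogen on an aromatic ring. Within the data shown here, the only measured step that bears on the same position is a 1.3-fold higher number from compound 1 to compound 2 (0.11 log units; within the scatter), a small one, which suggests that the group on this nitrogen has so far had little effect on the read-out. Compound 3 is therefore expected to show essentially no shift beyond the scatter, with an estimated step of a 1.1-fold lower number from compound 2 to compound 3 (0.05 log units; within the scatter). The estimated value of compound 3 in this assay is 12000 nM, within a range from 5000 nM to 30000 nM.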

Compound 3, half-maximal inhibitory concentration: 32100 nM
Compound 3: the middle estimate sits 2.7-fold (0.43 log units) below what was measured; the measured number lies above the stated range.
By their numbers in this assay, from the lowest: compounds 1 and 2 (each within the scatter of the next); then compound 3.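

With 4-ethoxyphenyl in place of 3-nitrophenyl, the read-out in this assay shows a 2.4-fold higher number from compound 2 to compound 3 (0.38 log units; beyond the scatter), so the group on this nitrogen can move the number beyond the scatter, which the swap from octyl to 3-nitrophenyl had not done. The replacement of octyl by 4-ethoxyphenyl likewise gives a 3.1-fold higher number from compound 1 to compound 3 (0.49 log units; beyond the scatter), which sets compound 3 apart from both compound 1 and compound 2, although both steps are modest. Nothing available explains why this group behaves differently from the other two.

The compounds shown leave open whether the step belongs to the ethoxy group itself or to its place on the phenyl ring, which a plain phenyl or a 3-ethoxyphenyl on this nitrogen would help to separate. Also open, on these data alone, is how a shorter chain such as butyl would read here, set against octyl.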